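The source may hold more compounds than are shown below. What is called first, only, known or untested is meant among the compounds shown, and "the series" means these compounds.

Measured compounds in an assay (Rattus norvegicus) for binding affinity to prostacyclin receptor (Homo sapiens), read by radioligand binding; on this read-out higher numbers stand for weaker inhibition and lower numbers for stronger inhibition: compound 1, `CC/N=C(\N)NCc1ccc(Sc2ccc(Cl)cc2)cc1`, gives < 10000 nM in this assay. For compound 1 this value is a limit of the assay, not a number (the limit of < 10000 nM in this assay, at which 1 of the 3 values shown sits). Compound 2, `COc1ccc(OC)c(Sc2ccc(NC3=NCCN3)cc2)c1`, gives 794 nM in this assay. Compound 3, `CCOc1ccc(Sc2ccc(NC3=NCCN3)cc2)cc1`, gives 39.8 nM in this assay, the lowest of the two numbers on record; its nearest neighbour is compound 2, whose value sits beyond the scatter above it. Among the compounds with values here, no pair among the measured compounds differs in a single place, so no measured step is available for calibration.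

Compound 4, `CS(=O)(=O)Nc1ccc(Sc2ccc(NC3=NCCN3)cc2)cc1`, has not been measured. It differs from compound 3 in one place: methanesulfonamido in place of ethoxy on an aromatic carbon. Within the series the only comparison of ring substituents is between compound 2 and compound 3, which differ in more than one place and so give no clean step. Without a measured step, the expectation for compound 4 is a loss, of the size given by the step below, and is held loosely. The step from compound 3 to compound 4 is estimated as a 3.8-fold higher number from compound 3 to compound 4 (0.58 log units; beyond the scatter) in this assay. For compound 4 the estimated value in this assay is 150 nM, expected to fall between 30 nM and 800 nM.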

Compound 4, inhibition constant: 79.4 nM
Compound 4: the middle estimate sits 1.9-fold (0.28 log units) above what was measured; the measured number falls inside the stated range.
By their numbers in this assay, from the lowest: compounds 3 and 4 (each within the scatter of the next); then compound 2.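

In this assay, within the data shown here, methanesulfonamido in place of ethoxy on this aromatic carbon, para to a large group, gives a 2.0-fold higher number from compound 3 to compound 4 (0.30 log units; within the scatter), the first single-place step that can be read. The earlier compounds shown here gave no clean comparison at this position, and this step shows that two quite different groups leave the read-out within the scatter of each other: ethoxy has 3 heavy atoms and 0 hydrogen-bond donors, while methanesulfonamido has 5 heavy atoms and 1 hydrogen-bond donor. Nothing on record explains why the two groups read alike, and the one available note, on the limit of compound 1, has no bearing on this step.

From the compounds shown here alone, whether the same holds for an amine, a carboxylic acid or a longer alkoxy chain on this carbon stays open, so a single step sets no range for what the position accepts. Also open, going by these compounds, is whether methanesulfonamido in place of ethoxy would read the same way on the core of compound 2, which carries two methoxy groups on its ring.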